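The source may hold more compounds than are shown below. What is called first, only, known or untested is meant among the compounds shown, and "the series" means these compounds.

In an ADME assay on microsomes (Homo sapiens) for metabolic stability (a higher number here means that the compound lasts longer, a lower number that the compound disappears faster), compound 1 `O=C(C1CCCC1)N1N=CCC1c1ccccc1` gives 1.13 h. Compound 2 `O=C(C1CCN(C(=O)C(F)(F)F)CC1)N1N=CCC1c1ccccc1` is reported as > 1.5 h, which is a limit of the assay and not a number. For the measured compounds named here, compound 2 therefore has no exact half-life, and no step between measured compounds that differ in one place is available to serve as a guide.

Compound 3 `O=C(c1c[nH]nn1)N1CCC(C(=O)N2N=CCC2c2ccccc2)CC1` has not yet been measured in this assay. It differs from compound 2 by having 1H-1,2,3-triazol-4-yl in place of trifluoromethyl on a carbonyl carbon. The group that enters brings a five-membered aromatic ring, while the group that leaves has no ring.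

Going by the values given here, with no measured precedent for this exchange, no change beyond the usual scatter is expected. The estimated step of a number no higher from compound 2 to compound 3 (the limit leaves the size open) is accordingly expected to be small, with no clear direction. This expectation rests on compound 2, whose limit of > 1.5 h is the nearest reference. For compound 3, the expected half-life is 1.5 h, with an estimated range from 0.8 h to 3 h.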

Compound 3, half-life: > 2.75 h
Compound 3: no number, only a limit; the forecaster's own chance of this, stated with the estimate: 55%; middle value at least 1.8-fold (0.26 log units) away from the limit.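

In this assay, for the compounds shown here, compound 2 and compound 3 are each reported only as a limit of the assay and not as a number, so no step between them can be read. The compounds shown leave open how long either compound actually lasts, and whether 1H-1,2,3-triazol-4-yl in place of trifluoromethyl on a carbonyl carbon changes the half-life at all.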